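The compounds below may be only part of what the source reports. "The series", "measured", "known", "first", "only" and "open" are said of these compounds alone.

Measured compounds in a functional assay on MCF7 cells (Homo sapiens) for antiproliferative activity, read by MTT assay, with a stated time of 24 h; on this read-out lower numbers stand for stronger inhibition and higher numbers for weaker inhibition:

Compound 1 `O=C1O/C(=C\Cn2cc(Cc3ccccc3)nn2)C(OCc2ccccc2)=C1OCc1ccccc1` gives 40000 nM in this assay.
Compound 2 `Cc1ccc(-c2cn(C/C=C3\OC(=O)C(OCc4ccccc4)=C3OCc3ccccc3)nn2)cc1` gives only a limit in this assay, > 100000 nM.
Compound 3 `O=C1O/C(=C\Cn2cc(C3=CCCCC3)nn2)C(OCc2ccccc2)=C1OCc1ccccc1` gives only a limit in this assay, > 100000 nM.

Within the data shown here, compound 3 thus stands at the upper limit of this assay, together with compound 2, as the limit of > 100000 nM in this assay, at which 2 of the 3 values shown sit, records; compound 1 is the only member of the series with a number rather than a limit. The step to the unmeasured compound 4 `O=C1O/C(=C\Cn2cc(-c3ccccn3)nn2)C(OCc2ccccc2)=C1OCc1ccccc1` is pyridin-2-yl in place of cyclohex-1-en-1-yl on an aromatic carbon.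

Among the measured compounds shown here, two measured steps bear on it. The change from benzyl to a ring attached directly to the triazole carbon gave an at least 2.5-fold higher number from compound 1 to compound 2 (0.39 log units; beyond the scatter) and an at least 2.5-fold higher number from compound 1 to compound 3 (0.39 log units; beyond the scatter); between the two directly attached rings the step is a step that the two limits leave unreadable from compound 2 to compound 3. Pyridin-2-yl is again a six-membered ring bound directly to that carbon, so no step beyond the scatter is expected from compound 3, and compound 4 will most likely also return only a limit in this assay.

Compound 4 is therefore estimated at 90000 nM in this assay, within 25000 nM to 250000 nM. The expected step is an at least 1.1-fold lower number from compound 3 to compound 4 (0.04 log units; that floor lies within the scatter).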

Compound 4, half-maximal inhibitory concentration: > 100000 nM
Compound 4: a limit, no number; the forecaster's own chance of this, stated with the estimate: 60%; middle value at least 1.1-fold (0.04 log units) from the limit.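

With pyridin-2-yl, a six-membered aromatic ring with a hetero atom and a hydrogen-bond acceptor now stands on this aromatic carbon, and the change from benzyl gives an at least 2.5-fold higher number from compound 1 to compound 4 (0.39 log units; beyond the scatter) in this assay. The loss seen with the 4-methylphenyl and cyclohex-1-en-1-yl groups is therefore also seen with this ring, which adds a ring nitrogen, and compound 1 remains the one exception, with a measured number. Compound 2, compound 3 and compound 4 now form a group at one assay ceiling, and the steps among them cannot be read: the limit of > 100000 nM in this assay, at which 3 of the 4 values shown sit.

Open, from the compounds shown here alone, is whether a measurable value needs benzyl itself or would also appear with a longer chain such as 2-phenylethyl, or with an aminomethyl group on the same carbon. Going by these compounds, the true values of compound 2, compound 3 and compound 4 also remain unknown.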